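The source may report more compounds than this note shows. Statements on the series, on what has been measured and on what is new or still open speak of the compounds shown alone.

Measured so far in an ADME assay on MDCK cells (Canis lupus familiaris) for cytotoxicity; on this read-out higher numbers stand for lower toxicity in this test and lower numbers for higher toxicity in this test:
compound 1 `O=[N+]([O-])C1=NNc2nc(C(F)(F)F)nn2C1O`, 40000 nM
compound 2 `O=[N+]([O-])C1=CNc2nc(-c3ccco3)nn2C1c1ccc(O)cc1O`, 119000 nM
compound 3 `O=[N+]([O-])C1=CNc2nc(-c3ccco3)nn2C1c1c(O)cc(O)cc1O`, 280000 nM

Compound 3 stands highest of the three numbers, with compound 2 next and compound 1 lowest, both gaps beyond the scatter. Going by the values given here, the only measured step, a 2.4-fold higher number from compound 2 to compound 3 (0.37 log units; beyond the scatter), concerns hydroxy in place of hydrogen on an aromatic carbon and does not touch the change now in hand. Compound 4 `O=[N+]([O-])C1=CNc2ncnn2C1c1c(O)cc(O)cc1O` differs from compound 3 by hydrogen in place of furan-2-yl on an aromatic carbon. Among the compounds with values here, no measured pair removes furan-2-yl; compound 1 carries trifluoromethyl at that position but differs elsewhere as well, so it offers no clean comparison. With nothing to point either way, a step near zero is expected: a 1.1-fold lower number from compound 3 to compound 4 (0.05 log units; within the scatter). Compound 4 is therefore estimated at 250000 nM, with a range of 110000 nM to 560000 nM.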

Compound 4, half-maximal cytotoxic concentration: > 1030000 nM
Compound 4: a limit, no number (the forecaster's own chance of this, stated with the estimate: 20%); middle value at least 4.1-fold (0.61 log units) from the limit.
By their numbers in this assay, from the lowest: compound 1; then compound 2; then compound 3. At a limit, above all of these: compound 4.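

In this assay, going by these compounds alone, hydrogen in place of furan-2-yl on this aromatic carbon gives an at least 3.6-fold higher number from compound 3 to compound 4 (0.56 log units; beyond the scatter), the first clean reading of a change at this position. The position therefore affects this read-out, and furan-2-yl is not needed for a high number in this test. Compound 4 gives a limit and not a number, so the step has no upper size: the limit of > 1030000 nM in this assay, at which 1 of the 4 values shown sits.

From the compounds shown here alone, whether any group at this position would lower the number as furan-2-yl does remains open. A methyl group or an amine there would help to settle this.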